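Methoxy to trifluoromethyl on a shared core

This account rests on a few compounds, and the source may have more. Where it says the series, first, only, none or still open, it means among the compounds named here.

Compound 1 `C1=C(c2cccnc2)CC2CNCC1C2` – 0.2 nM
Compound 2 `Clc1cncc(C2=CC3CNCC(C2)C3)c1` – 0.4 nM
Compound 3 `COc1cncc(C2=CC3CNCC(C2)C3)c1` – 0.3 nM

All three numbers come from an in vitro assay on SH-EP1 cells for displacement of a labelled ligand from Neuronal acetylcholine receptor; alpha4/beta2 (Homo sapiens); a higher number here means a weaker inhibitor, a lower number a stronger inhibitor. Compound 3 stands second highest of the three, and both of its neighbours sit within the scatter of it: a 1.3-fold lower number from compound 2 to compound 3 (0.12 log units; within the scatter) and a 1.5-fold higher number from compound 1 to compound 3 (0.18 log units; within the scatter). The remaining pairing, a 2.0-fold higher number from compound 1 to compound 2 (0.30 log units; within the scatter), is also within the scatter, so across these three compounds the group on that aromatic carbon has not shifted the number beyond what repeated measurements would show.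

Compound 4 `FC(F)(F)c1cncc(C2=CC3CNCC(C2)C3)c1` has not been measured. It differs from compound 3 by trifluoromethyl in place of methoxy on an aromatic carbon. Among the compounds with values here, the steps that bear on this change are the ones that add or exchange a group at the same aromatic carbon, a 1.5-fold higher number from compound 1 to compound 3 (0.18 log units; within the scatter) and a 1.3-fold lower number from compound 2 to compound 3 (0.12 log units; within the scatter), together with a 2.0-fold higher number from compound 1 to compound 2 (0.30 log units; within the scatter). None of them moved the number beyond the scatter. Trifluoromethyl has not been tried on this core, so the expectation rests only on that small spread. Compound 4 is therefore expected to give about 0.5 nM in this assay, with a likely range from 0.15 nM to 2 nM. The step this estimate implies is a 1.7-fold higher number from compound 3 to compound 4 (0.22 log units; within the scatter), which is expected to stay within the scatter.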

Compound 4, inhibition constant: 0.7 nM
Compound 4: middle estimate off by 1.4-fold (0.15 log units), on the low side, within the range that was stated.
By their numbers in this assay, from the lowest: compounds 1, 3, 2 and 4 (each within the scatter of the next, the first and the last beyond it).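

At this aromatic carbon, trifluoromethyl is the first group shown to move the number in this assay beyond the scatter, although only modestly, in both the exchange for methoxy (a 2.3-fold higher number from compound 3 to compound 4 (0.37 log units; beyond the scatter)) and the comparison with hydrogen (a 3.5-fold higher number from compound 1 to compound 4 (0.54 log units; beyond the scatter)). The exchange for chloro stays within the scatter (a 1.8-fold higher number from compound 2 to compound 4 (0.24 log units; within the scatter)), so compound 4 stands apart from compound 1 and compound 3 but not from compound 2, and the change from methoxy counts as a real but small step only when set against that limit. Methoxy and trifluoromethyl differ both in heavy atoms and in hydrogen-bond acceptors, and nothing measured here separates those two differences or explains the shift.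

The compounds shown cover only hydrogen, chloro, methoxy and trifluoromethyl on this one aromatic carbon, so it remains open whether an amine, a carboxylic acid or a longer chain would be tolerated there or would move the number much further. On these data alone, it also remains open whether trifluoromethyl would give a similar step at another carbon of the same aromatic ring.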